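Phenyl replaces isopropyl on an oxalamide ester

A few compounds are considered here, and "the series" means these few. Any claim that something is new, unique, unknown or untested is made for them only; others in the source may bear on it.

Of the compounds shown here, two have been measured in a functional assay on the whole organism (strain Sprague-Dawley CD) for inhibition, with Rattus norvegicus as the target, read by paw edema, at a dose of 10 mg/kg by the intraperitoneal route; on this read-out lower numbers stand for a weaker effect and higher numbers for a stronger effect at the one dose given. Compound 1, `CCOC(=O)C(=O)Nc1ccccc(O)c1=O`, gives 5% in this assay. Among the compounds with values here, compound 2, `CC(C)OC(=O)C(=O)Nc1cccccc1=O`, gives 76% in this assay, and on these two numbers compound 2 stands highest, with compound 1 as its only neighbour at a value far enough below it to lie beyond the usual scatter. Within the data shown here, compound 1 and compound 2 differ in more than one place, so no single step between them can be read from their values.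

Compound 3, `O=C(Nc1cccccc1=O)C(=O)Oc1ccccc1`, is the compound next in line and has not yet been measured in this assay. It differs from compound 2 in one place only: phenyl in place of isopropyl on an oxygen next to a carbonyl group. The shared core and the oxalamide linkage stay as they are in compound 2. Among the measured compounds shown here, nothing among the measured compounds shows what this exchange does on its own, so the expectation for compound 3 rests on compound 2 alone, with a step of a number 21 percentage points lower from compound 2 to compound 3 (beyond the scatter) expected, downward and likely beyond the scatter but uncertain in size. Compound 3 is therefore estimated at 55% in this assay, within a range from 25% to 85%.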

Compound 3, a percentage reported as inhibition, in the whole organism at one dose (the size of the read-out at that dose, not a potency): 68%
Beside the measured number, compound 3's estimate is 13 percentage points below it; measured number inside the range.
By their numbers in this assay, from the lowest: compound 1; then compounds 3 and 2 (each within the scatter of the next).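

Within the data shown here, the exchange of isopropyl for phenyl on an oxygen next to a carbonyl group amounts to a number 8 percentage points lower from compound 2 to compound 3 (within the scatter) in this assay, which is the first comparison here that isolates a single place. At the one dose given, this read-out does not separate the two groups, so this position can carry either the open three-carbon isopropyl or the six-carbon aromatic ring, and the read-out of compound 3 stays within the scatter of that of compound 2. No evidence at hand bears on this result.

As far as these compounds go, it remains open whether other groups at this position, such as a benzyl group, a longer chain or a phenyl ring bearing a methoxy group, would stay within the same scatter, and whether an amine in place of the oxygen would do so. Steps involving compound 1 cannot be read, since it differs from compound 2 and compound 3 in more than one place, so the compounds shown do not tell which of those differences goes with its much lower value.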